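A few compounds are considered here, and "the series" means these few. Any claim that something is new, unique, unknown or untested is made for them only; others in the source may bear on it.

Measured so far in a functional assay on M21 cells (Homo sapiens) for antiproliferative activity, read by sulforhodamine B assay, with a stated time of 48 h; on this read-out higher numbers stand for weaker inhibition and lower numbers for stronger inhibition:
compound 1 `Cc1ccc(NS(=O)(=O)c2ccc(N3CCNC3=O)cc2)cc1C` — 94 nM.
compound 2 `CC(C)(C)c1ccc(NS(=O)(=O)c2ccc(N3CCNC3=O)cc2)cc1` — > 1000 nM.
compound 3 `O=C1NCCN1c1ccc(S(=O)(=O)Nc2ccc(OC(F)F)cc2)cc1` — 410 nM.

The value of compound 2 is a limit of this assay, (the limit of > 1000 nM in this assay, at which 1 of the 3 values shown sits). Among the two numbers, compound 1 gives the lower one, and compound 3 sits clearly higher. For the measured compounds named here, the only measured step at the aryl group on the sulfonamide nitrogen is an at least 2.4-fold lower number from compound 2 to compound 3 (0.38 log units; beyond the scatter), so changes at that group move this assay, but no step with an ortho-substituted variant is available.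

Compound 4 `Cc1ccccc1NS(=O)(=O)c1ccc(N2CCNC2=O)cc1` differs from compound 1 by 2-methylphenyl in place of 3,4-dimethylphenyl on a sulfonamide nitrogen. Since compound 3 already stands well above compound 1 after a change at the same group, a modest weakening is expected, a 2.7-fold higher number from compound 1 to compound 4 (0.42 log units; beyond the scatter). Compound 4 is estimated at 250 nM, within 80 nM to 800 nM.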

Compound 4, half-maximal inhibitory concentration: 150 nM
Compound 4: the middle estimate sits 1.7-fold (0.22 log units) above what was measured; the measured number falls inside the stated range.
By their numbers in this assay, from the lowest: compounds 1 and 4 (each within the scatter of the next); then compound 3. At a limit, above all of these: compound 2.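

In this assay there is a 1.6-fold higher number from compound 1 to compound 4 (0.20 log units; within the scatter) with 2-methylphenyl in place of 3,4-dimethylphenyl on a sulfonamide nitrogen. Unlike the earlier step at this group, this one does not separate the two aryl groups, so this position accepts either of them in this assay. No measured property available here bears on this step.

On these data alone, whether an aryl group carrying an amine or a carboxylic acid would hold this level remains open. So does the effect of a longer alkyl chain in place of the methyl of 2-methylphenyl.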